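The source may report more compounds than this note shows. Statements on the series, on what has been measured and on what is new or still open speak of the compounds shown alone.

Of the compounds shown here, three built on one shared core have been measured in an ADME assay on A549 cells (Homo sapiens) for cytotoxicity, read by resazurin assay, with a stated time of 48 h; on this read-out lower numbers stand for higher toxicity in this test and higher numbers for lower toxicity in this test. Compound 1 `CCNc1ccc(NC(=O)c2cc(Cl)ccc2O)c(Cl)c1` gives 30200 nM in this assay. Compound 2 `CCCNc1ccc(NC(=O)c2cc(Cl)ccc2O)c(Cl)c1` gives 22500 nM in this assay, and compound 3 `CN(C)c1ccc(CNc2ccc(NC(=O)c3cc(Cl)ccc3O)c(Cl)c2)cc1` gives 24500 nM in this assay. Among these three numbers compound 3 stands second highest. Its nearest neighbour is compound 2, and between the two there is a 1.1-fold higher number from compound 2 to compound 3 (0.04 log units; within the scatter). Its furthest neighbour is compound 1, and between those two there is a 1.2-fold lower number from compound 1 to compound 3 (0.09 log units; within the scatter). The remaining pair shows a 1.3-fold lower number from compound 1 to compound 2 (0.13 log units; within the scatter).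

Compound 4 `O=C(Nc1ccc(NCCCO)cc1Cl)c1cc(Cl)ccc1O` has not yet been measured in this assay. Compared with compound 3 the change is this: 2-hydroxyethyl in place of 4-(dimethylamino)phenyl on a saturated chain carbon bound to a nitrogen on an aromatic ring. For the measured compounds named here, the steps that bear on this change are those which altered the group on the same saturated chain carbon bound to a nitrogen on the aromatic ring, namely a 1.2-fold lower number from compound 1 to compound 3 (0.09 log units; within the scatter) and a 1.1-fold higher number from compound 2 to compound 3 (0.04 log units; within the scatter), and the neighbouring chain change a 1.3-fold lower number from compound 1 to compound 2 (0.13 log units; within the scatter); every one of them stayed within the scatter. Going by the values given here, nothing measured so far therefore points to a step beyond the scatter in this assay for compound 4. The expected step is a 1.0-fold lower number from compound 3 to compound 4 (0.01 log units; within the scatter). Compound 4 is accordingly estimated to give about 24000 nM in this assay, with a range from 12000 nM to 48000 nM.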

Compound 4, half-maximal cytotoxic concentration: 106000 nM
Compound 4: the middle estimate sits 4.4-fold (0.65 log units) below what was measured; the measured number lies above the stated range.
By their numbers in this assay, from the lowest: compounds 2, 3 and 1 (each within the scatter of the next); then compound 4.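

In this assay, for the compounds shown here, compound 4 is the only one of the four compounds whose steps to the others all lie beyond the scatter, and it has the highest number, which here stands for the lowest toxicity in this test. Adding hydroxy to the otherwise unchanged chain of compound 2 gives a 4.7-fold higher number from compound 2 to compound 4 (0.67 log units; beyond the scatter), whereas the earlier changes at this position, including the replacement of the ethyl of compound 2 by 4-(dimethylamino)phenyl, all stayed within the scatter. The same direction appears in a 3.5-fold higher number from compound 1 to compound 4 (0.55 log units; beyond the scatter) and, where 2-hydroxyethyl replaces 4-(dimethylamino)phenyl, in a 4.3-fold higher number from compound 3 to compound 4 (0.64 log units; beyond the scatter), but nothing available explains why these steps arise.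

The compounds shown leave open whether this step is specific to hydroxy or whether a methoxy, an amine or a carboxylic acid on the same saturated chain carbon would give a similar number. They also leave open whether hydroxy would give a step of similar size on a shorter or longer chain, so one compound does not define a trend for this position.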